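The source may report more compounds than this note shows. Statements on the series, on what has been measured and on what is new or still open speak of the compounds shown alone.

Four analogues share one core. Compound 1 `CCCSc1nc(N[C@@H]2C[C@H]2c2ccc(F)c(F)c2)c2nnn([C@@H]3C[C@H](OC(C)=O)[C@@H](O)[C@H]3O)c2n1` has no result in a functional assay on the whole organism (strain Sprague-Dawley) for inhibition, with Rattus norvegicus as the target, with a stated time of 0.5 h, at a dose of 5 mg/kg by the oral route (on this read-out lower numbers stand for less inhibition and higher numbers for more inhibition at the one dose given (going by the name of the read-out)), its entry reading "not determined" (no result reported). Compound 2 `CCCSc1nc(N[C@@H]2C[C@H]2c2ccc(F)c(F)c2)c2nnn([C@@H]3C[C@H](OC(=O)C(C)(C)C)[C@@H](O)[C@H]3O)c2n1` is recorded in this assay as "not active" (no number reported), without a number. Compound 3 `CCCSc1nc(N[C@@H]2C[C@H]2c2ccc(F)c(F)c2)c2nnn([C@@H]3C[C@H](OC(=O)OCC)[C@@H](O)[C@H]3O)c2n1` therefore stands alone: in this assay compound 3 gives 42.6%, the only figure among the three. Compound 4 `CCCSc1nc(N[C@@H]2C[C@H]2c2ccc(F)c(F)c2)c2nnn([C@@H]3C[C@H](OC(=O)c4ccccc4)[C@@H](O)[C@H]3O)c2n1` is not yet measured. It differs from compound 3 by phenyl in place of ethoxy on a carbonyl carbon. Going by the values given here, with no measured pair to lean on, and with compound 2 showing that a change at this carbonyl carbon can remove the read-out entirely, the step from compound 3 to compound 4 is expected to be a modest fall, a number 12.6 percentage points lower from compound 3 to compound 4 (beyond the scatter), probably beyond the scatter. Compound 4 is estimated at 30%, within a range from 5% to 55%.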

Compound 4, a percentage reported as inhibition, in the whole organism at one dose (the size of the read-out at that dose, not a potency): 20.1%
For compound 4 the middle estimate is 9.9 percentage points above the measured one, within the range that was stated.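

In this assay, going by these compounds alone, the change from (ethoxycarbonyl)oxy to benzoyloxy gives a number 22.5 percentage points lower from compound 3 to compound 4 (beyond the scatter), the first measured step at this position. It shows that the group on this carbonyl carbon changes the size of the read-out, and that a phenyl there still leaves a number, whereas compound 2 is recorded as "not active" (no number reported). Nothing given here explains the fall. The compounds shown leave open how an amine or a longer alkoxy chain on this carbonyl carbon would read in this assay. With a single step, they also establish no trend.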